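This account rests on a few compounds, and the source may have more. Where it says the series, first, only, none or still open, it means among the compounds named here.

Measured so far:
Compound 1 `Nc1ccc2cccc(OC3CCCCCC3)c2n1`: 137 nM in an assay on cells with melanin-concentrating hormone receptor 1 (Homo sapiens) as the target, read by radioligand binding; a lower number here means a stronger inhibitor, a higher number a weaker inhibitor
Compound 2 `CCC(C)COc1cccc2ccc(N)nc12`: 36 nM in this assay

Compound 2 holds the lowest of the two numbers; compound 1 sits at a higher number, and that gap lies beyond the usual scatter. The step from compound 2 to compound 3 `CC(C)(C)CCOc1cccc2ccc(N)nc12` changes only the chain: neopentyl in place of sec-butyl on a saturated chain carbon bound to an oxygen on an aromatic ring. Within the data shown here, no measured pair shows this change, so nothing in the data fixes its size. The expectation for this assay is a step of a 1.1-fold higher number from compound 2 to compound 3 (0.05 log units; within the scatter), not beyond the scatter in either direction. Compound 3 is accordingly estimated at 40 nM, within a range of 15 nM to 120 nM.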

Compound 3, half-maximal inhibitory concentration: 201 nM
Beside the measured number, compound 3's estimate is 5.0-fold (0.70 log units) below it; measured number outside the range, above it.
By their numbers in this assay, from the lowest: compound 2; then compounds 1 and 3 (each within the scatter of the next).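

In this assay, exchanging sec-butyl for neopentyl on a saturated chain carbon bound to an oxygen on an aromatic ring gives a 5.6-fold higher number from compound 2 to compound 3 (0.75 log units; beyond the scatter), so this position clearly tells apart two chains that both have no ring and no net charge. The change leaves compound 3 within the scatter of compound 1, which carries a cycloheptyl group there. No measurement shown here speaks to the reason for this step.

Still open, as far as these compounds go, is whether a longer unbranched chain, or a chain ending in an amine or a carboxylic acid, would match compound 2 at this position.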